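The source may report more compounds than this note shows. Statements on the series, on what has been measured and on what is new or still open speak of the compounds shown alone.

Of the compounds shown here, three sharing one core have been measured in a functional assay on HEL cells (Homo sapiens) (a higher number here means that more compound is tolerated, a lower number that less compound is tolerated), and all three results are limits rather than numbers. Compound 2, `CCCCCCc1cc2cn(COCCO)c(=O)nc2o1`, gives > 200000 nM, which is a limit of this assay and not a measured number. Compound 2 therefore stands at the limit of > 200000 nM in this assay, at which 1 of the 3 values shown sits, while the two other values shown stand at the limit of > 50000 nM in this assay, at which 2 of the 3 values shown sit. Compound 1, `CCCCCCC#Cc1cc2cn(COCCO)c(=O)nc2o1`, gives > 50000 nM, again a limit. Compound 3, `CCCCCCCC#Cc1cc2cn(COCCO)c(=O)nc2o1`, gives > 50000 nM, also a limit. Within the data shown here, the only step between measured compounds that differ in one place, a step that the two limits leave unreadable from compound 1 to compound 3, runs from one limit to the same limit and so cannot be read in size or direction.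

Compound 4, `CCCCCCCCCc1cc2cn(COCCO)c(=O)nc2o1`, is not yet measured. It differs from compound 2 by propyl in place of hydrogen on a saturated chain carbon, six bonds along the chain from an aromatic carbon. Among the measured compounds shown here, the one measured step that resembles this change, a lengthening of a saturated chain, is the step from compound 1 to compound 3, and its size is not readable. For the measured compounds named here, no measured step thus tells the size of the change in this assay, and the expectation is that compound 4 is again tolerated up to a limit, with a step of an at least 2.0-fold lower number from compound 2 to compound 4 (0.30 log units; that floor lies within the scatter) expected between them. Compound 4 is estimated at 100000 nM, with a range from 30000 nM to 300000 nM.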

Compound 4, half-maximal cytotoxic concentration: >= 100000 nM
Compound 4: only a limit was reported; the forecaster's own chance of this, stated with the estimate: 80%; the middle value sits exactly at the limit.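

In this assay compound 2 gives > 200000 nM, which is a limit and not a number. Compound 4 gives >= 100000 nM, also a limit. The step between these two compounds therefore cannot be read in size or direction. The compounds shown leave open the concentration at which any of them harms the cells in this assay, and whether chain length changes it at all.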